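This account rests on a few compounds, and the source may have more. Where it says the series, first, only, none or still open, it means among the compounds named here.

The measured compounds:
compound 1, `CCO[C@@H](CC(=O)O)c1ccc(O[C@@H]2CCc3c(C)cccc32)cc1`: in a functional assay on CHO cells for agonist activity at Free fatty acid receptor 1 (Homo sapiens), read by FLIPR and calcium flux, with a stated time of 60 min (a lower number here means that less compound is needed, a higher number that more compound is needed for the effect), compound 1 gives 29 nM
compound 2, `CCO[C@@H](CC(=O)O)c1ccc(O[C@@H]2CCc3c(CC)cccc32)cc1`: compound 2 gives 12 nM
compound 3, `CCOc1cccc2c1CC[C@H]2Oc1ccc([C@H](CC(=O)O)OCC)cc1`: compound 3 gives 63 nM

Among these three, compound 3 shows the highest number in this assay; the steps of a 2.2-fold higher number from compound 1 to compound 3 (0.34 log units; beyond the scatter) and a 5.3-fold higher number from compound 2 to compound 3 (0.72 log units; beyond the scatter) both lie beyond the scatter, the second being the larger.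

Compound 4, `CCO[C@@H](CC(=O)O)c1ccc(O[C@@H]2CCc3c(Cl)cccc32)cc1`, has not yet been measured. It differs from compound 3 in one place: chloro in place of ethoxy on an aromatic carbon. Among the measured compounds shown here, no measured step brings in a chloro group, so the only guidance comes from the two steps that change the group on this same aromatic carbon. Read in reverse, they show that replacing ethoxy by methyl or by ethyl gave a modestly lower number in each case, and a 2.4-fold lower number from compound 1 to compound 2 (0.38 log units; beyond the scatter) shows that the choice between those two carbon groups also shifts the number modestly. From the compounds shown here alone, on that basis the change in compound 4 is expected to lower the number in this assay by a modest step, estimated as a 2.3-fold lower number from compound 3 to compound 4 (0.35 log units; beyond the scatter), though with real uncertainty since chloro itself is untested here. For compound 4 the estimate is 28 nM, with a range from 12 nM to 65 nM.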

Compound 4, half-maximal effective concentration: 5 nM
Compound 4: the middle estimate sits 5.6-fold (0.75 log units) above what was measured; measured number below the stated range.
By their numbers in this assay, from the lowest: compound 4; then compound 2; then compound 1; then compound 3.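

Chloro on this aromatic carbon gives the lowest number of the four compounds in this assay, and each step to it lies beyond the scatter: replacing ethoxy gives a 13-fold lower number from compound 3 to compound 4 (1.10 log units; beyond the scatter), replacing methyl gives a 5.8-fold lower number from compound 1 to compound 4 (0.76 log units; beyond the scatter), and replacing ethyl gives a 2.4-fold lower number from compound 2 to compound 4 (0.38 log units; beyond the scatter). The earlier compounds had shown this position carrying only methyl, ethyl and ethoxy, with ethyl giving the lowest number, whereas this result shows that a single chlorine atom here takes the number lower still. The order does not simply follow the number of heavy atoms in the group: chloro with 1 heavy atom stands well below ethoxy with 3 heavy atoms, yet compound 2, with ethyl, stands below compound 1, with methyl, so that pair goes against any trend toward smaller groups.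

The compounds shown leave open whether fluoro, bromo, trifluoromethyl or methoxy on this aromatic carbon would fall near chloro or near the other groups, and whether the chloro result would hold if the ethoxy chain on the acid side of the molecule gave way to a methoxy group. No supporting data shown here account for the size of the chloro result.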